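Piperidin-1-yl in place of hexylamino on a carbonyl carbon

A few compounds are considered here, and "the series" means these few. Any claim that something is new, unique, unknown or untested is made for them only; others in the source may bear on it.

Within the data shown here, the series has two measured members so far. In a functional assay on the whole organism with Homo sapiens as the target (a lower number here means that less compound is needed, a higher number that more compound is needed for the effect), compound 1 (`CC(O)(C(=O)Nc1ccccc1Cl)C(F)(F)F`) gives 5400 nM, and compound 2 (`CCCCCCNC(=O)c1ccc(NC(=O)C(C)(O)C(F)(F)F)c(Cl)c1`) gives 5500 nM. Compound 2 therefore stands level with compound 1, as the two values lie within the scatter of each other, even though the two structures differ substantially.

Compound 3 (`CC(O)(C(=O)Nc1ccc(C(=O)N2CCCCC2)cc1Cl)C(F)(F)F`) is the next to be read in this assay. It carries piperidin-1-yl in place of hexylamino on a carbonyl carbon. Among the measured compounds shown here, no measured pair differs in one place only, so this change has no direct precedent and the forecast is uncertain. For the measured compounds named here, the only guide is the level pair of compound 1 at 5400 nM and compound 2 at 5500 nM. A modest step towards a lower number is expected, close to the edge of the scatter, and a step too small to resolve remains possible. The expected change is a 2.2-fold lower number from compound 2 to compound 3 (0.34 log units; beyond the scatter). For compound 3 the estimated value is 2500 nM, with an expected range of 500 nM to 8000 nM.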

Compound 3, half-maximal effective concentration: 710 nM
Estimate against measurement, compound 3: 3.5-fold (0.55 log units) above, and the stated range covers the measured number.
By their numbers in this assay, from the lowest: compound 3; then compounds 1 and 2 (each within the scatter of the next).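

In this assay the group on this carbonyl carbon proves to matter: piperidin-1-yl in place of hexylamino gives a 7.7-fold lower number from compound 2 to compound 3 (0.89 log units; beyond the scatter). Adding a substituted carbonyl to the aromatic carbon does not by itself set the number, as compound 2 at 5500 nM stands level with compound 1 at 5400 nM, whereas (piperidin-1-yl)carbonyl in place of hydrogen on an aromatic carbon gives a 7.6-fold lower number from compound 1 to compound 3 (0.88 log units; beyond the scatter). No measurement at hand explains whether the ring or the loss of the hydrogen-bond donor counted for hexylamino carries this step.

The compounds shown leave open whether the ring itself is needed or an open-chain group without the amide hydrogen, such as diethylamino, would give a similar number. They also leave open how far the step depends on the size and make-up of the group on the carbonyl carbon, which pyrrolidin-1-yl, morpholin-4-yl or a shorter chain such as ethylamino in the same place would begin to show.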